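Sulfonyl group exchange from compound 3 to compound 4

The source may report more compounds than this note shows. Statements on the series, on what has been measured and on what is new or still open speak of the compounds shown alone.

Measured in an ADME assay (liver) for metabolic stability, with Liver microsome (Homo sapiens) as the target, read by LC-MS, using microsomes and NADPH, with a stated time of 5 min, at 37 degrees C; on this read-out higher numbers stand for fast clearance and lower numbers for slow clearance:
- compound 1 `CCn1c([C@@H](C)NS(=O)(=O)c2ccc(Cl)cc2)nc2cc(C#N)ccc21`: 71 mL.min-1.g-1
- compound 2 `CCn1c(C(C)NS(=O)(=O)c2ccc(Cl)cc2)nc2cnccc21`: 35 mL.min-1.g-1
- compound 3 `CCn1c([C@@H](C)NS(=O)(=O)c2ccc(C#N)cc2)nc2ccc(C(F)(F)F)cc21`: 34 mL.min-1.g-1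

Compound 3 at 34 mL.min-1.g-1 sits within the scatter of compound 2 at 35 mL.min-1.g-1. Measured against compound 3, compound 1 at 71 mL.min-1.g-1 gives a higher number, and that gap lies beyond the scatter. For the measured compounds named here, three values form a thin base, and no pair of measured compounds differs in one place only.

Compound 4 `CCn1cc(S(=O)(=O)N[C@H](C)c2nc3ccc(C(F)(F)F)cc3n2CC)cn1` has 1-ethyl-1H-pyrazol-4-yl in place of 4-cyanophenyl on a sulfonyl sulfur. Going by the values given here, none of the measured compounds carries this group, so the data hold no direct measure of the exchange. The starting point for the expectation is therefore compound 3 at 34 mL.min-1.g-1, with a wide margin on either side.

No step beyond the scatter is expected in this assay, and the estimated change is a 1.1-fold lower number from compound 3 to compound 4 (0.05 log units; within the scatter). For compound 4 the estimated value is 30 mL.min-1.g-1, with an expected range of 12 mL.min-1.g-1 to 70 mL.min-1.g-1.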

Compound 4, intrinsic clearance in microsomes: 95 mL.min-1.g-1
The estimate for compound 4 lay 3.2-fold (0.50 log units) below the measured number; measured number above the stated range.
By their numbers in this assay, from the lowest: compounds 3 and 2 (each within the scatter of the next); then compounds 1 and 4 (each within the scatter of the next).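

In this assay the sulfonyl sulfur proves sensitive to exchange: 1-ethyl-1H-pyrazol-4-yl in place of 4-cyanophenyl gives a 2.8-fold higher number from compound 3 to compound 4 (0.45 log units; beyond the scatter) with the rest of the molecule unchanged. For the compounds shown here, this is the only one-place comparison so far, and it gives the first direct reading for this position, with the direction towards faster clearance. The step does not separate the contribution of the five-membered aromatic ring from that of its ethyl group, or the effect of losing the 4-cyanophenyl from that of adding the new group, and nothing at hand bears on the origin of the change.

Open, as far as these compounds go, is whether the ethyl group on the ring matters, which 1-methyl-1H-pyrazol-4-yl or an unsubstituted 1H-pyrazol-4-yl on the same sulfonyl sulfur would help to settle. Also open is whether the step carries over to the other cores shown, where a 4-chlorophenyl group occupies the sulfonyl sulfur, as one-place pairs on those cores would show.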